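The source may hold more compounds than are shown below. What is called first, only, known or untested is meant among the compounds shown, and "the series" means these compounds.

Compound 3 `COc1ccc(-n2nc(C(=O)Nc3ccc(Oc4ccnc5cc(OCCCN6CCCCC6)c(OC)cc45)c(F)c3)c(C)cc2=O)cc1` gives 3730 nM in a functional assay on NCI-H460 cells (Homo sapiens) for inhibition, read by MTT assay, with a stated time of 72 h (a lower number here means a stronger inhibitor, a higher number a weaker inhibitor), the highest number among the three measured compounds. Compound 1 `COc1cc2c(Oc3ccc(NC(=O)c4nn(-c5ccccc5C(F)(F)F)c(=O)cc4C)cc3F)ccnc2cc1OCCCN1CCCCC1` gives 210 nM and compound 2 `COc1cc2c(Oc3ccc(NC(=O)c4nn(-c5ccccc5OC(F)(F)F)c(=O)cc4C)cc3F)ccnc2cc1OCCCN1CCCCC1` gives 230 nM; the step of a 1.1-fold higher number from compound 1 to compound 2 (0.04 log units; within the scatter) is within the scatter. Two steps are large: an 18-fold higher number from compound 1 to compound 3 (1.25 log units; beyond the scatter) and a 16-fold higher number from compound 2 to compound 3 (1.21 log units; beyond the scatter). Compound 4 `COc1cc2c(Oc3ccc(NC(=O)c4nn(-c5ccc(Cl)cc5Cl)c(=O)cc4C)cc3F)ccnc2cc1OCCCN1CCCCC1` carries 2,4-dichlorophenyl in place of 4-methoxyphenyl on an aromatic nitrogen, on an aromatic nitrogen next to the ring nitrogen. Both large steps bear on this change; in each, the 4-methoxyphenyl left and a phenyl bearing a single group entered. For the measured compounds named here, the 2,4-dichlorophenyl carries two chlorines, and no measured compound shows the weight of the second. A step back toward the numbers of compound 1 and compound 2 is expected, a 12-fold lower number from compound 3 to compound 4 (1.09 log units; beyond the scatter). Compound 4 is estimated at 300 nM, between 120 nM and 900 nM.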

Compound 4, half-maximal inhibitory concentration: 390 nM
The estimate for compound 4 lay 1.3-fold (0.11 log units) below the measured number; measured number inside the range.
By their numbers in this assay, from the lowest: compounds 1, 2 and 4 (each within the scatter of the next); then compound 3.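

In this assay, the 2,4-dichlorophenyl on the aromatic nitrogen moves well away from the number of compound 3 (a 9.6-fold lower number from compound 3 to compound 4 (0.98 log units; beyond the scatter)). The steps to compound 4 from the ortho-substituted aryl compounds stay within the scatter (a 1.7-fold higher number from compound 2 to compound 4 (0.23 log units; within the scatter); a 1.9-fold higher number from compound 1 to compound 4 (0.27 log units; within the scatter)). Among these four compounds, three different aryl groups at this position therefore give indistinguishable numbers, and only the 4-methoxyphenyl of compound 3 stands apart.

On these data alone, whether both chlorines of the 2,4-dichlorophenyl are needed remains open, as does the outcome with an aminomethyl or a carboxylic acid on that phenyl. No measurement shown gives a reason for the gap.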